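The source may report more compounds than this note shows. Statements on the series, on what has been measured and on what is new or still open speak of the compounds shown alone.

Measured compounds in the series:

compound 1 `COc1ccc(-c2cc(C(=O)/C=C/c3ccccc3)nc3cc(-c4ccccc4)nn23)cc1OC`; in a functional assay on A549 cells (Homo sapiens) for antiproliferative activity, read by MTT assay, with a stated time of 24 h (a higher number here means a weaker inhibitor, a lower number a stronger inhibitor), compound 1 gives 18600 nM
compound 2 `COc1ccc(-c2cc(C(=O)/C=C/c3ccc(C)cc3)nc3cc(-c4ccccc4)nn23)cc1OC`; in this assay compound 2 gives 22200 nM
compound 3 `COc1cc(-c2cc(C(=O)/C=C/c3ccccc3)nc3cc(-c4ccccc4)nn23)cc(OC)c1OC`; in this assay compound 3 gives 18000 nM

On these three numbers compound 1 stands second highest, with compound 3 nearest (a 1.0-fold lower number from compound 1 to compound 3 (0.01 log units; within the scatter)) and compound 2 furthest (a 1.2-fold higher number from compound 1 to compound 2 (0.08 log units; within the scatter)); both steps lie within the scatter, so the three compounds are not separated by this assay.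

Compound 4 `COc1ccc(-c2cc(/C=C/C(=O)c3ccc(C)cc3)nc3cc(-c4ccccc4)nn23)cc1OC` is not yet measured. It differs from compound 1 in one place: 2-((4-methylphenyl)carbonyl)ethenyl in place of (2-phenylethenyl)carbonyl on an aromatic carbon. Two parts make up this change. The methyl on the carbon-only aromatic ring has a measured counterpart, the step from compound 1 to compound 2 (a 1.2-fold higher number from compound 1 to compound 2 (0.08 log units; within the scatter)), which stayed within the scatter. Going by the values given here, the reversal of the carbonyl and ethenyl order has no measured counterpart among the three compounds, so nothing in the data speaks for a shift in either direction. The step expected from compound 1 to compound 4 is therefore none beyond the scatter (a 1.1-fold higher number from compound 1 to compound 4 (0.03 log units; within the scatter)). Compound 4 is estimated at 20000 nM in this assay, with a range from 7000 nM to 55000 nM.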

Compound 4, half-maximal inhibitory concentration: 17200 nM
Beside the measured number, compound 4's estimate is 1.2-fold (0.07 log units) above it; the range from low to high includes it.
By their numbers in this assay, from the lowest: compounds 4, 3, 1 and 2 (each within the scatter of the next).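

Going by these compounds alone, the reversal of the carbonyl and ethenyl order, untouched by the earlier compounds, can now be read at this position next to the ring nitrogen. The cleanest reading is a 1.3-fold lower number from compound 2 to compound 4 (0.11 log units; within the scatter), as both compounds carry the methyl on the carbon-only aromatic ring, while a 1.1-fold lower number from compound 1 to compound 4 (0.03 log units; within the scatter) combines the reversal with that methyl. In this assay neither step separates the two orders, and no supporting data bear on the reason for this.

Still open, going by these compounds, is whether a carboxylic acid or an amine on this aromatic carbon, in place of the whole carbonyl-ethenyl group, would move the number beyond the scatter. Also open, on these data alone, is whether the two orders would stay together with a hydroxyl or a chlorine on the carbon-only aromatic ring.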